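Methoxy in Place of Chloro on the Sulfonyl Aryl Group

A few compounds are considered here, and "the series" means these few. Any claim that something is new, unique, unknown or untested is made for them only; others in the source may bear on it.

Compound 1 `Cc1ccc(S(=O)(=O)c2cnc3ccc(Cl)cc3c2N2CCC(C)CC2)cc1C` gives 84% in an assay on isolated protein for displacement of a labelled ligand from metabotropic glutamate receptor 5 (Homo sapiens), with a stated time of 60 min, tested at 1 uM; on this read-out higher numbers stand for more inhibition at the one concentration tested (going by the name of the read-out) and lower numbers for less inhibition.
Compound 2 `CC1CCN(c2c(S(=O)(=O)c3ccc(F)cc3)cnc3ccc(Cl)cc23)CC1` gives 89% in this assay.
Compound 3 `CC1CCN(c2c(S(=O)(=O)c3ccc(Cl)c(Cl)c3)cnc3ccc(Cl)cc23)CC1` gives 86% in this assay.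

Compound 3 stands second highest of the three numbers in this assay, yet all three sit close together: the step of a number 2 percentage points higher from compound 1 to compound 3 (within the scatter) and the step of a number 3 percentage points lower from compound 2 to compound 3 (within the scatter) both lie within the scatter, as does a number 5 percentage points higher from compound 1 to compound 2 (within the scatter). The three compounds share the same core and differ only in the aryl group on the sulfonyl sulfur, and none of those exchanges moved the read-out beyond the scatter.

Compound 4 `COc1ccc(S(=O)(=O)c2cnc3ccc(Cl)cc3c2N2CCC(C)CC2)cc1Cl` changes that same aryl group once more: methoxy in place of chloro on an aromatic carbon. The three measured steps all concern this aryl group, and each was small; they therefore point to no step beyond the scatter for this change either. Compound 4 is accordingly expected to sit near compound 3, with an expected step of a number 2 percentage points lower from compound 3 to compound 4 (within the scatter). The estimate for compound 4 in this assay is 84%, in a range from 70% to 94%.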

Compound 4, a percentage reported as inhibition, at one concentration (the size of the read-out at that concentration, not a potency): 46%
Beside the measured number, compound 4's estimate is 38 percentage points above it; measured number below the stated range.
By their numbers in this assay, from the lowest: compound 4; then compounds 1, 3 and 2 (each within the scatter of the next).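

Exchanging one chloro for methoxy on the sulfonyl aryl group gives a number 40 percentage points lower from compound 3 to compound 4 (beyond the scatter) in this assay, so this position, para to a large group, does not accept every substituent, although the earlier aryl exchanges all stayed within the scatter. The fall appears against the other two aryl groups as well, with a number 43 percentage points lower from compound 2 to compound 4 (beyond the scatter) and with a number 38 percentage points lower from compound 1 to compound 4 (beyond the scatter) in the same read-out, so it does not hang on one reference compound. No measurement shown here bears on why the number falls.

On these data alone, it remains open whether the oxygen or the added carbon of methoxy matters more, which a hydroxyl or an ethoxy at this position could help to separate. An amine there, or a longer alkoxy chain, is also still an open case.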